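Replacing the 3-chlorophenyl group of compound 1

The source may report more compounds than this note shows. Statements on the series, on what has been measured and on what is new or still open speak of the compounds shown alone.

For the measured compounds named here, in a functional assay on COLO 205 cells (Homo sapiens) for inhibition, read by sulforhodamine B assay (on this read-out lower numbers stand for stronger inhibition of growth and higher numbers for weaker inhibition of growth), compound 1 `Cc1ccc2[nH]c(-c3ccc(-c4ccc(-c5cccc(Cl)c5)cc4)cc3)nc2c1` gives 2780 nM, the lowest of the three numbers measured so far. Compound 2 `CN(C)c1ccc(-c2ccc(-c3ccc(-c4nc5ccccc5[nH]4)cc3)cc2)cc1` gives 100000 nM, and compound 3 `Clc1cccc(-c2ccc(-c3ccc(-c4nc5ccccc5[nH]4)cc3)cc2)c1` gives 100000 nM. Losing the methyl group, with hydrogen in its place, is a large step: a 36-fold higher number from compound 1 to compound 3 (1.56 log units; beyond the scatter). Exchanging one aryl group for another, with no methyl present, moved nothing: no change at the digits printed from compound 2 to compound 3 (within the scatter).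

Compound 4 `Cc1ccc2[nH]c(-c3ccc(-c4ccc(-c5ccc(OC(F)(F)F)cc5)cc4)cc3)nc2c1` keeps the methyl group and changes the aryl group instead: 4-(trifluoromethoxy)phenyl in place of 3-chlorophenyl on an aromatic carbon. In words, 4-(trifluoromethoxy)phenyl stands in place of 3-chlorophenyl. Going by the values given here, the step between compound 2 and compound 3 is the only measured aryl exchange, and it is a weak guide, as no aryl exchange has been measured with the methyl group present. The large methyl step does not apply, since the methyl group stays. In this assay, the expected step is a 1.3-fold higher number from compound 1 to compound 4 (0.10 log units; within the scatter), an estimate that lies within the scatter. Compound 4 is therefore expected near 3500 nM, with an estimated range of 1000 nM to 30000 nM.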

Compound 4, concentration for 50% growth inhibition: 30600 nM
Compound 4: middle estimate off by 8.7-fold (0.94 log units), on the low side, and the stated range ends below it.
By their numbers in this assay, from the lowest: compound 1; then compound 4; then compounds 2 and 3 (each within the scatter of the next).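

With the methyl group present, the aryl group at this place clearly matters: in this assay, 4-(trifluoromethoxy)phenyl in place of 3-chlorophenyl gives an 11-fold higher number from compound 1 to compound 4 (1.04 log units; beyond the scatter). For the compounds shown here, the only earlier aryl exchange, made without the methyl group, gave no change at the digits printed from compound 2 to compound 3 (within the scatter), so this is the first sign that the number responds to this part of the molecule. No measurement shown here accounts for the size of this step.

This exchange alters both the substituent and where it sits on the ring, so the two changes cannot be told apart; a 4-chlorophenyl group on the methyl-bearing core would separate them. On these data alone, it also remains open how an unsubstituted phenyl group or a phenyl group carrying a carboxylic acid would behave at this place.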